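Ring stereocentre drawn and undrawn: one step forward

This account rests on a few compounds, and the source may have more. Where it says the series, first, only, none or still open, it means among the compounds named here.

Measured so far:
compound 1 `CC[C@]1(c2ccccc2)OC(=O)N(C)C1=O` – 69 mg/kg
compound 2 `O=C1O[C@]2(c3ccccc3)CCCCCN1C2=O` – < 400 mg/kg

Going by the values given here, in a functional assay on the whole organism with Mus musculus as the target, with a stated time of 0.5 h (on this read-out lower numbers stand for an effect already at smaller amounts and higher numbers for an effect only at larger amounts of compound), compound 1 gives 69 mg/kg, the only number in the set. For compound 2 this assay returns only a limit, < 400 mg/kg, which is not a number. Among the compounds with values here, the set holds (the limit of < 400 mg/kg in this assay, at which 1 of the 2 values shown sits), so no measured step is available and nothing within it gauges any change.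

Compound 3 `CCC1(c2ccccc2)OC(=O)N(C)C1=O` differs from compound 1 in this way: the two compounds have the same atoms and bonds; at least one stereo element is drawn with a configuration in one of them and without one in the other: 1 of 1 stereo elements differ; a stereocentre at a saturated ring carbon is drawn R in compound 1 and without a configuration in compound 3. Within the data shown here, no measured step of this kind exists here, so the size is judged from the change alone. The dose for compound 3 is expected to stay close to that of compound 1 or move modestly upward, with a step of a 1.4-fold higher number from compound 1 to compound 3 (0.16 log units; within the scatter) expected to sit near the edge of the scatter. Compound 3 is estimated at 100 mg/kg, within 50 mg/kg to 200 mg/kg.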

Compound 3, dose for half-maximal effect: 45 mg/kg
Compound 3: the middle estimate sits 2.2-fold (0.35 log units) above what was measured, and the stated range ends above it.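

With a 1.5-fold lower number from compound 1 to compound 3 (0.19 log units; within the scatter) in this assay, the series now holds its first measured step, and that step lies within the scatter. At this saturated ring carbon, the stereocentre drawn R and the same centre drawn without a configuration are therefore not told apart by this read-out, so a drawn configuration here carries no measurable weight in the data so far. The two structures offer only one difference to set against this step: the fact that one of compounds 1 and 3 is drawn with a defined configuration and the other without, at the place where they differ

Still open, going by these compounds, is how a compound drawn S at this stereocentre would read, and whether a longer chain or an amine on the core of compound 1 would shift the dose beyond the scatter. Going by these compounds alone, compound 2 stands at < 400 mg/kg, which is a limit and not a number, so it adds no step.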